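The source may hold more compounds than are shown below. What is called first, only, known or untested is meant among the compounds shown, and "the series" means these compounds.

Measured compounds:
- compound 1 `CC(C)N(Cc1cccc(OCCCCCC(=O)O)c1)C(=O)c1ccc(-c2cccc(Cl)c2)cc1`: in an ADME assay on HEK293 cells (Homo sapiens) for cytotoxicity, read by CellTiter-Glo and resazurin assay, with a stated time of 72 h (a lower number here means that less compound is needed, a higher number that more compound is needed for the effect), compound 1 gives > 21900 nM, a limit of the assay.
- compound 2 `CC(C)N(Cc1cccc(OCCCCCC(=O)O)c1)C(=O)c1ccc(-c2cccc(S(C)(=O)=O)c2)cc1`: in this assay compound 2 gives > 26000 nM, also a limit.
- compound 3 `CCOC(=O)CCCCCOc1cccc(CN(C(=O)c2ccc(-c3cccc(Cl)c3)cc2)C(C)C)c1`: in this assay compound 3 gives > 18400 nM, again a limit.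

The change methylsulfonyl in place of chloro on an aromatic carbon is seen once among the measured pairs and gives a step that the two limits leave unreadable from compound 1 to compound 2; compound 1 sits at the limit of > 21900 nM in this assay, at which 1 of the 3 values shown sits, and compound 2 at the limit of > 26000 nM in this assay, at which 1 of the 3 values shown sits, so no size can be read. The two cores differ by ethyl in place of hydrogen on an oxygen next to a carbonyl group, which gives a step that the two limits leave unreadable from compound 1 to compound 3, with compound 3 at the limit of > 18400 nM in this assay, at which 1 of the 3 values shown sits.

Compound 4 `CCOC(=O)CCCCCOc1cccc(CN(C(=O)c2ccc(-c3cccc(S(C)(=O)=O)c3)cc2)C(C)C)c1` is not yet measured. It differs from compound 3 by methylsulfonyl in place of chloro on an aromatic carbon, the same change as from compound 1 to compound 2, at a place described in the same words. The expected step is a step that the limit leaves unreadable from compound 3 to compound 4, resting on the fact that compound 1 and compound 2 both sit at limits the limit of > 21900 nM in this assay, at which 1 of the 3 values shown sits, and (the limit of > 26000 nM in this assay, at which 1 of the 3 values shown sits), so the change is expected to leave the readout at a limit again. For compound 4 the estimate in this assay is 30000 nM, expected between 15000 nM and 60000 nM.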

Compound 4, half-maximal effective concentration: > 26000 nM
Compound 4: no number, only a limit (the forecaster's own chance of this, stated with the estimate: 85%); the middle value is on the limit's open side.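

No step can be read in this assay: compound 4 stands at a limit of the assay, as do compound 2 and compound 3, so neither of its comparisons has a size. The compounds shown leave open at what concentration any of the four reaches the half-maximal effect, and how much either change alters it.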